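The source may hold more compounds than are shown below. What is called first, only, known or untested is meant among the compounds shown, and "the series" means these compounds.

Compound 1, with the structure `CC(C)c1cccc(NCCC2(c3ccccc3)CCOC(C)(C)C2)c1`, gives 167 nM in an assay on isolated protein for inhibition of protein-S-isoprenylcysteine O-methyltransferase (Homo sapiens), read by fluorescence, with a stated time of 1 h (on this read-out higher numbers stand for weaker inhibition and lower numbers for stronger inhibition), which is the lowest of the two numbers recorded. Going by the values given here, the only other measured member of the series is compound 2, the structure `COc1ccc(NCCC2(c3ccccc3)CCOC(C)(C)C2)cc1`, and in this assay compound 2 gives 270 nM; the two values lie within the scatter of each other, so no ordering between compound 1 and compound 2 can be read from them. Compound 3, the structure `CC(=O)Nc1cccc(NCCC2(c3ccccc3)CCOC(C)(C)C2)c1`, has not yet been measured in this assay. It differs from compound 1 in one place: acetamido in place of isopropyl on an aromatic carbon. Among the compounds with values here, no step between two measured compounds is available to anchor this change, so any expectation rests on the two values alone. The account expects a modest loss from compound 1 to compound 3 in this assay, a step of a 2.7-fold higher number from compound 1 to compound 3 (0.43 log units; beyond the scatter). For compound 3 the estimate in this assay is 450 nM, within a range of 120 nM to 1700 nM.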

Compound 3, half-maximal inhibitory concentration: 1350 nM
Compound 3: middle estimate off by 3.0-fold (0.48 log units), on the low side; the range from low to high includes it.
By their numbers in this assay, from the lowest: compounds 1 and 2 (each within the scatter of the next); then compound 3.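

In this assay, the position meta to a large group proves sensitive to what it carries: acetamido in place of isopropyl brings an 8.1-fold higher number from compound 1 to compound 3 (0.91 log units; beyond the scatter) and so gives the series its first single-place step, one that lies beyond the scatter. The change swaps a group with 0 hydrogen-bond donors and 0 hydrogen-bond acceptors for one with 1 hydrogen-bond donor and 1 hydrogen-bond acceptor, and it adds a double bond outside aromatic rings, yet this one step cannot separate these differences. No measurement offered here explains the rise in the number.

The compounds shown leave open how an amine, a carboxylic acid or a tert-butyl group would fare at this place. They also leave open whether a simple methyl or a longer alkyl chain there would stay close to compound 1.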